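A Smaller, Hydroxylated Side Chain at the Amide Carbon

A few compounds are considered here, and "the series" means these few. Any claim that something is new, unique, unknown or untested is made for them only; others in the source may bear on it.

Of the compounds shown here, three built on one shared core have been measured in a functional assay on the whole organism (Tail, strain ICR) with Mus musculus as the target, in the tail flick test, with a stated time of 120 min, at a dose of 25 umol/kg by the oral route; on this read-out higher numbers stand for a stronger effect at the one dose given and lower numbers for a weaker effect. Compound 3 `O=C(CN(c1nc(Cl)nc2[nH]cnc12)C1CC1)N[C@@H](CCC(=O)OCc1ccccc1)C(=O)OCc1ccccc1` gives 45.9% in this assay, the highest of the three numbers. Compound 1 `CSCC[C@H](NC(=O)CN(c1nc(Cl)nc2[nH]cnc12)C1CC1)C(=O)OCc1ccccc1` gives 31.6%, and compound 2 `O=C(CN(c1nc(Cl)nc2[nH]cnc12)C1CC1)NCC(=O)OCc1ccccc1` gives 21.7%. The three differ only in the group on the saturated chain carbon bound to an amide-type nitrogen and a carbonyl carbon.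

Compound 4 `C[C@@H](O)[C@H](NC(=O)CN(c1nc(Cl)nc2[nH]cnc12)C1CC1)C(=O)OCc1ccccc1` has not yet been measured. It changes compound 3 at that same place: 1-hydroxyethyl in place of 2-(benzyloxycarbonyl)ethyl on a saturated chain carbon bound to an amide-type nitrogen and a carbonyl carbon.

Among the measured compounds shown here, two measured steps bear on this change. Adding the full side chain to the bare carbon gave a number 24.2 percentage points higher from compound 2 to compound 3 (beyond the scatter), and exchanging the smaller 2-(methylsulfanyl)ethyl for it gave a number 14.3 percentage points higher from compound 1 to compound 3 (beyond the scatter). Among these three compounds the larger group at this carbon goes with the higher number, and 1-hydroxyethyl is smaller than either of the groups in compound 1 or compound 3. A drop beyond the scatter is therefore expected for compound 4, which is estimated to give 28%, within a range from 12% to 44%. This estimate means an expected step of a number 17.9 percentage points lower from compound 3 to compound 4 (beyond the scatter).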

Compound 4, a percentage reported as activity, at one dose (the size of the read-out at that dose, not a potency): 30.7%
Beside the measured number, compound 4's estimate is 2.7 percentage points below it; measured number inside the range.
By their numbers in this assay, from the lowest: compounds 2, 4 and 1 (each within the scatter of the next); then compound 3.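

In this assay, the drop in side-chain size comes with a step beyond the scatter (a number 15.2 percentage points lower from compound 3 to compound 4 (beyond the scatter)), so the 1-hydroxyethyl group does not keep the higher number seen with 2-(benzyloxycarbonyl)ethyl. Compound 4 cannot be separated from the compounds with smaller groups at this carbon (a number 0.9 percentage points lower from compound 1 to compound 4 (within the scatter); a number 9 percentage points higher from compound 2 to compound 4 (within the scatter)), so the link between larger groups and higher numbers now rests on compound 3 alone, and hydrogen, 2-(methylsulfanyl)ethyl and 1-hydroxyethyl form one group within the scatter. Nothing given here explains the result.

Still open, as far as these compounds go, is which part of the large side chain matters: the aromatic ring, the ester, or simply the chain length. A carboxylic acid at the chain end, or a plain longer carbon chain, would help to separate these.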